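Cytotoxicity notes on a triazolopyrimidine series

This account rests on a few compounds, and the source may have more. Where it says the series, first, only, none or still open, it means among the compounds named here.

Measured so far:
- compound 1 `Cc1cc(Nc2cc(-c3ccccc3)[nH]n2)n2nc(SCc3nc4ccccc4[nH]3)nc2n1`: 27800 nM
- compound 2 `Cc1cc(Nc2ccn(Cc3nc(C)c4ccccc4n3)n2)n2nc(SCc3ccc(Br)cc3)nc2n1`: 36800 nM
- compound 3 `Cc1nc2nc(SCc3ccc(Cl)cc3)nn2c(Nc2cc(-c3ccccc3)[nH]n2)c1C`: 47200 nM

In an ADME assay on GES1 cells (Homo sapiens) for inhibition, read by MTT assay, with a stated time of 72 h (a higher number here means a weaker inhibitor, a lower number a stronger inhibitor), compound 1 gives 27800 nM, the lowest of the three numbers, though both compound 2 and compound 3 stand within the scatter of it, so no order among the three can be read. Compound 4 `COc1ccc(CSc2nc3nc(C)cc(Nc4cc(-c5ccccc5)[nH]n4)n3n2)cc1` differs from compound 1 in one place: 4-methoxyphenyl in place of 1H-benzimidazol-2-yl on a saturated chain carbon bound to a sulfur. Among the compounds with values here, no measured pair separated by a single change is available to calibrate this step. Given that compound 2 and compound 3, which also carry a benzyl-type group on the sulfur, return values within the scatter of compound 1, compound 4 is expected to land close to compound 1, with the step of a 1.3-fold higher number from compound 1 to compound 4 (0.10 log units; within the scatter) estimated as none beyond the scatter. The estimate for compound 4 in this assay is 35000 nM, with a range from 15000 nM to 80000 nM.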

Compound 4, half-maximal inhibitory concentration: 28200 nM
Estimate against measurement, compound 4: 1.2-fold (0.09 log units) above; the range from low to high includes it.
By their numbers in this assay, from the lowest: compounds 1, 4, 2 and 3 (each within the scatter of the next).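

Within the data shown here, replacing 1H-benzimidazol-2-yl with 4-methoxyphenyl on a saturated chain carbon bound to a sulfur gives the only single-place comparison; in this assay the step reads a 1.0-fold higher number from compound 1 to compound 4 (0.01 log units; within the scatter) in this position. A group with a five-membered aromatic ring and a hydrogen-bond donor thus gives way to one with neither, with no shift beyond the scatter. No measurement at hand offers an explanation for this result.

Going by these compounds, whether an amine or a carboxylic acid at this place would shift the number remains open. So does the effect of a longer chain between the sulfur and the aromatic ring.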